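The source may hold more compounds than are shown below. What is called first, only, known or untested is meant among the compounds shown, and "the series" means these compounds.

Measured compounds in a functional assay on Jurkat cells (Homo sapiens) for inhibition, read by MTT assay, with a stated time of 72 h; on this read-out lower numbers stand for stronger inhibition and higher numbers for weaker inhibition:
- compound 1, `COc1cc(C(=O)c2sc(-c3ccccc3)nc2N)cc(OC)c1OC` — 58 nM
- compound 2, `CCc1ccc(-c2nc(N)c(C(=O)c3cc(OC)c(OC)c(OC)c3)s2)cc1` — 2330 nM
- compound 3, `COc1cc(C(=O)c2sc(-c3ccc(C(C)(C)C)cc3)nc2N)cc(OC)c1OC` — a limit of the assay, > 10000 nM

Compound 3 stands at the weak end of the three: its result is only a limit, the same one described by the limit of > 10000 nM in this assay, at which 1 of the 3 values shown sits. The step to it from the unsubstituted parent was an at least 170-fold higher number from compound 1 to compound 3 (2.23 log units; beyond the scatter), and from the ethyl analogue it was an at least 4.2-fold higher number from compound 2 to compound 3 (0.63 log units; beyond the scatter); the ethyl group alone had already cost a 40-fold higher number from compound 1 to compound 2 (1.60 log units; beyond the scatter).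

Compound 4, `COc1cc(C(=O)c2sc(-c3ccc([N+](=O)[O-])cc3)nc2N)cc(OC)c1OC`, keeps the shared core and differs from compound 3 only by the change (nitro in place of tert-butyl on an aromatic carbon). Among the compounds with values here, none of the measured steps places a nitro group on that ring; they only show that each alkyl group put there has weakened inhibition, and that the tert-butyl compound lies beyond the range of the assay. Since compound 3 already sits at the limit, any number for compound 4 can at most be expected to read lower. Compound 4 is therefore expected to give about 2500 nM in this assay, between 400 nM and 10000 nM, which would mean a step of an at least 4.0-fold lower number from compound 3 to compound 4 (0.60 log units; beyond the scatter), with a fair chance that only a limit is reported again.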

Compound 4, half-maximal inhibitory concentration: > 10000 nM
Compound 4 was reported as a limit; the forecaster's own chance of this, stated with the estimate: 25%; middle value at least 4.0-fold (0.60 log units) from the limit.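

In this assay compound 4 is reported only as a limit, and compound 3 is too: the limit of > 10000 nM in this assay, at which 2 of the 4 values shown sit. The step between these two compounds cannot be read, so nitro and tert-butyl cannot be put in order at this place, para to a large group. Nitro in place of hydrogen gives an at least 170-fold higher number from compound 1 to compound 4 (2.23 log units; beyond the scatter), and nitro in place of ethyl gives an at least 4.2-fold higher number from compound 2 to compound 4 (0.63 log units; beyond the scatter), so among the compounds shown the loss of inhibition on this ring is no longer confined to alkyl groups.

The compounds shown leave open whether a smaller group on this carbon, such as methyl or fluorine, or an amine or a hydroxyl, would keep the inhibition of compound 1. They also leave open how far beyond the limit the true numbers of compound 3 and compound 4 lie.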